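The compounds below may be only part of what the source reports. "The series", "measured", "known", "first", "only" and "open" are said of these compounds alone.

Measured so far in a functional assay for inhibition of sodium/hydrogen exchanger (Oryctolagus cuniculus); on this read-out lower numbers stand for stronger inhibition and higher numbers for weaker inhibition:
compound 1, `Cc1ccc(-c2ccc(C(=O)N=C(N)N)cc2S(C)(=O)=O)cc1`, 100 nM
compound 2, `CS(=O)(=O)c1cc(C(=O)N=C(N)N)ccc1C(F)(F)F`, 140 nM
compound 3, `COc1ccc(C(=O)N=C(N)N)cc1S(C)(=O)=O`, 270 nM

Compound 3 carries the highest number of the three: a 2.7-fold higher number from compound 1 to compound 3 (0.43 log units; beyond the scatter), whereas a 1.9-fold higher number from compound 2 to compound 3 (0.29 log units; within the scatter). The unmeasured compound 4, `CS(=O)(=O)c1cc(C(=O)N=C(N)N)ccc1Oc1cccnc1`, differs from compound 3 in one place: pyridin-3-yl in place of methyl on an oxygen on an aromatic ring. Going by the values given here, no measured pair alters the group on that oxygen, so the bearing comes only from the steps on the aromatic carbon that carries it, where methoxy stands against a group with a ring or with three fluorines; those gave a 2.7-fold higher number from compound 1 to compound 3 (0.43 log units; beyond the scatter) and a 1.9-fold higher number from compound 2 to compound 3 (0.29 log units; within the scatter). Compound 4 restores a six-membered aromatic ring at that end of the molecule, and on that basis compound 4 is expected to land at 120 nM, with a range of 50 nM to 300 nM. The step of a 2.3-fold lower number from compound 3 to compound 4 (0.35 log units; beyond the scatter) is therefore estimated as a modest lowering of the number, roughly back to the level of compound 1, close to the edge of the scatter.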

Compound 4, half-maximal inhibitory concentration: 76 nM
For compound 4 the middle estimate is 1.6-fold (0.20 log units) above the measured one; the range from low to high includes it.
By their numbers in this assay, from the lowest: compounds 4, 1, 2 and 3 (each within the scatter of the next, the first and the last beyond it).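

In this assay the group on the oxygen can be changed from methyl to pyridin-3-yl with a gain, the only step shown that alters that group (a 3.6-fold lower number from compound 3 to compound 4 (0.55 log units; beyond the scatter)). At the aromatic carbon, (pyridin-3-yl)oxy is not separated from trifluoromethyl (a 1.8-fold lower number from compound 2 to compound 4 (0.27 log units; within the scatter)) or from 4-methylphenyl (a 1.3-fold lower number from compound 1 to compound 4 (0.12 log units; within the scatter)), so a group linked through oxygen reads like both directly attached groups. Nothing available explains the step from methoxy to (pyridin-3-yl)oxy.

Still open, from the compounds shown here alone, is whether the ring nitrogen of pyridin-3-yl counts, which phenyl on the same oxygen would show, and whether pyridin-2-yl or pyridin-4-yl reads the same. Also open, going by these compounds, is whether a longer chain on that oxygen, or an amine nitrogen in place of the oxygen, keeps the number at this level.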